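Chloro added to the benzyl arm of the shared core

A few compounds are considered here, and "the series" means these few. Any claim that something is new, unique, unknown or untested is made for them only; others in the source may bear on it.

compound 1 `C=CCn1nc(Cc2ccc(Cl)cc2)c2ccccc2c1=O`: 4400 nM
compound 2 `Cn1nc(Cc2ccccc2)c2ccccc2c1=O`: 1500 nM

Among the compounds with values here, in a functional assay on Vas deferens with Alpha-1A adrenergic receptor (Rattus norvegicus) as the target (a higher number here means that more compound is needed for the effect, a lower number that less compound is needed), compound 2 gives 1500 nM, the lowest of the two numbers so far. Its nearest neighbour, compound 1, gives 4400 nM, a gap beyond the scatter, but these two structures differ in more than one place, so no single step can be read from them. Compound 3 `Cn1nc(Cc2ccc(Cl)cc2)c2ccccc2c1=O` carries chloro in place of hydrogen on an aromatic carbon, para to a large group. Within the data shown here, with no single-point step measured, the expected step is a 1.2-fold higher number from compound 2 to compound 3 (0.08 log units; within the scatter), modest and not clearly beyond the scatter. In this assay compound 3 is estimated at 1800 nM, ranging from 600 nM to 5500 nM.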

Compound 3, half-maximal effective concentration: 810 nM
Compound 3: middle estimate off by 2.2-fold (0.35 log units), on the high side, within the range that was stated.
By their numbers in this assay, from the lowest: compounds 3 and 2 (each within the scatter of the next); then compound 1.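

In this assay, chloro in place of hydrogen on an aromatic carbon, para to a large group, gives a 1.9-fold lower number from compound 2 to compound 3 (0.27 log units; within the scatter), so adding chloro at this position leaves the number within the scatter. Within the data shown here, with chloro kept, hydrogen in place of vinyl on a saturated chain carbon bound to an aromatic nitrogen gives a 5.4-fold lower number from compound 1 to compound 3 (0.73 log units; beyond the scatter), the only single-place step here beyond the scatter. No measured data on the cause of either step are available.

Still open, on these data alone, is how a methoxy group or an amine on that aromatic carbon would read. As far as these compounds go, a longer chain on the aromatic nitrogen also remains open.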